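A few compounds are considered here, and "the series" means these few. Any claim that something is new, unique, unknown or untested is made for them only; others in the source may bear on it.

Compound 1 `c1ccc(Cc2nnc(SCCCN3CCN(c4ccccn4)CC3)[nH]2)cc1`: in a functional assay on COLO 205 cells (Homo sapiens) for cytotoxicity, read by MTT assay, with a stated time of 24 h (a higher number here means a weaker inhibitor, a lower number a stronger inhibitor), compound 1 gives only a limit, > 300000 nM.
Compound 2 `CC(C)(C)c1ccc(-c2nn(CCCN3CCN(c4ccccc4)CC3)c(=S)[nH]2)cc1`: in this assay compound 2 likewise gives only a limit, > 300000 nM.

Compound 2 thus stands at the limit of > 300000 nM in this assay, at which 2 of the 2 values shown sit, with no number of its own. The step to compound 3 `CC(C)(C)c1ccc(-c2nn(CCCN3CCN(c4cccc(Cl)c4)CC3)c(=S)[nH]2)cc1` is chloro in place of hydrogen on an aromatic carbon. For the measured compounds named here, no measured step between compounds bears on this change, and compound 1 differs from compound 2 in more than one place, so the two limits show only that both sit at the edge of the assay. For compound 3 the expected step is a number no higher from compound 2 to compound 3 (the limit leaves the size open), none beyond the scatter, and a limit is again the likely outcome. Compound 3 is therefore estimated at 300000 nM, between 100000 nM and 1000000 nM.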

Compound 3, half-maximal inhibitory concentration: > 300000 nM
Compound 3: a limit, no number (the forecaster's own chance of this, stated with the estimate: 85%); the middle value sits exactly at the limit.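

Compound 2 and compound 3 both give only a limit in this assay, so no step can be read between them. The compounds shown leave open whether chloro in place of hydrogen on the aromatic carbon changes the read-out at all.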